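Diarylidene series: cytotoxicity on Huh-7 cells

The source may hold more compounds than are shown below. What is called first, only, known or untested is meant among the compounds shown, and "the series" means these compounds.

Measured compounds:
- compound 1, `C=CCn1c(=O)/c(=C\c2ccccc2Cl)[nH]c(=O)/c1=C\c1ccccc1OC`: 6400 nM
- compound 2, `C=CCn1c(=O)/c(=C\c2ccc(F)c(Br)c2)[nH]c(=O)/c1=C\c1ccccc1OC`: "not active" (no number reported)
- compound 3, `C=CCn1c(=O)/c(=C\c2cccc(Br)c2)[nH]c(=O)/c1=C\c1cccc(Br)c1`: "not active" (no number reported)

Within the data shown here, in a functional assay on Huh-7 cells (Homo sapiens) for cytotoxicity, read by CCK-8 assay, with a stated time of 72 h (a higher number here means a weaker inhibitor, a lower number a stronger inhibitor), compound 1 gives 6400 nM and is the only member of the series with a number. In this assay compound 2 gives "not active" (no number reported). In this assay compound 3 gives "not active" (no number reported). Among the measured compounds shown here, no step between two measured compounds with a single change is available, so the effect of varying the aryl group on the double-bonded chain carbon is not quantified.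

Compound 4, `C=CCn1c(=O)/c(=C\c2cc(F)ccc2C)[nH]c(=O)/c1=C\c1ccccc1OC`, keeps the core and the 2-methoxyphenyl arm of compound 1 and differs only in one place: 5-fluoro-2-methylphenyl in place of 2-chlorophenyl on a double-bonded chain carbon bound to an aromatic carbon.

For the measured compounds named here, with no measured step to lean on, the expectation rests on compound 1 alone. In this assay compound 4 is estimated at 9000 nM, with a range from 3000 nM to 30000 nM. The expected step of a 1.4-fold higher number from compound 1 to compound 4 (0.15 log units; within the scatter) is small, toward weaker inhibition, and not beyond the scatter; the two entries without a number make an outcome without a number a real possibility.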

Compound 4, half-maximal inhibitory concentration: 5600 nM
Compound 4: the middle estimate sits 1.6-fold (0.21 log units) above what was measured; measured number inside the range.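

In this assay, among these compounds, 5-fluoro-2-methylphenyl in place of 2-chlorophenyl on a double-bonded chain carbon bound to an aromatic carbon gives a 1.1-fold lower number from compound 1 to compound 4 (0.06 log units; within the scatter), the first single-place step that can be read. This position therefore accepts this exchange of aryl groups with a numerical read-out retained and no change beyond the scatter, whereas, differing from compound 4 only at this place, compound 2 gives "not active" (no number reported). No measurement on hand bears on the reason for this result.

From the compounds shown here alone, since the fluorine and the methyl enter together, their separate contributions remain open. Also open, going by these compounds, is how an aryl group carrying an amine or a carboxylic acid would read at this place in this assay.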